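The compounds below may be only part of what the source reports. "The series", "measured", "known", "first", "only" and "open" are said of these compounds alone.

Measured compounds:
- Compound 1 `CC(C(=O)NCc1ccc(C(F)(F)F)nc1-c1ccccc1)c1ccc(NS(C)(=O)=O)c(F)c1`: 6.4 nM in an assay on CHO cells for antagonist activity at transient receptor potential cation channel subfamily V member 1 (Homo sapiens), read by FLIPR; a lower number here means a stronger inhibitor, a higher number a weaker inhibitor
- Compound 2 `CC(C(=O)NCc1ccc(C(F)(F)F)nc1-c1ccccc1F)c1ccc(NS(C)(=O)=O)c(F)c1`: 63.3 nM in this assay

Compound 2 gives the higher of the two numbers, with compound 1 the nearer of the two, as a 9.9-fold higher number from compound 1 to compound 2 (1.00 log units; beyond the scatter) shows. Compound 3 `CC(C(=O)NCc1ccc(C(F)(F)F)nc1-c1ccc(Cl)cc1)c1ccc(NS(C)(=O)=O)c(F)c1` differs from compound 2 by 4-chlorophenyl in place of 2-fluorophenyl on an aromatic carbon. Going by the values given here, no measured step covers this swap; the only related step, a 9.9-fold higher number from compound 1 to compound 2 (1.00 log units; beyond the scatter), concerns the fluorine that now leaves. For compound 3 the number in this assay is expected to fall between those of compound 1 and compound 2, with a 3.2-fold lower number from compound 2 to compound 3 (0.50 log units; beyond the scatter) as the estimated step, giving 20 nM (range 5 nM to 80 nM).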

Compound 3, inhibition constant: 0.7 nM
For compound 3 the middle estimate is 29-fold (1.46 log units) above the measured one, and the stated range ends above it.
By their numbers in this assay, from the lowest: compound 3; then compound 1; then compound 2.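

The phenyl ring on this carbon can take a substituent and give a lower number: chloro in place of hydrogen gives (a 9.1-fold lower number from compound 1 to compound 3 (0.96 log units; beyond the scatter)), the opposite direction to the fluoro of compound 2. The larger swap (a 90-fold lower number from compound 2 to compound 3 (1.96 log units; beyond the scatter)) changes both the halogen and its place on the ring, so this step alone cannot say which of the two matters. Nothing available here explains the difference.

As far as these compounds go, whether 4-fluorophenyl or 2-chlorophenyl would read like compound 2 or like compound 3 stays open. So does how 4-methoxyphenyl or 4-aminophenyl would behave in this assay.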